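A Nitrile-Bearing Benzyl Group Replaces a Small Amide

The compounds below may be only part of what the source reports. "The series", "measured", "known", "first", "only" and "open" are said of these compounds alone.

Of the compounds shown here, three have been measured in a functional assay (B cells) with Mus musculus as the target (a higher number here means that more compound is needed for the effect, a lower number that less compound is needed), all sharing one core. Compound 1 `C=CCn1/c(=N\C#N)n([C@H]2OC(CO)[C@@H](O)[C@H]2O)c2cc(N)nc(O)c21` gives 156 uM in this assay. Compound 2 `NC(=O)Cn1c(=O)n(C2OC(CO)[C@@H](O)[C@H]2O)c2nc(N)nc(O)c21` gives 190 uM, the highest of the three numbers, though the gap to compound 1 lies within the usual scatter, so the two cannot be told apart. Compound 3 `C=CCn1c(=O)n([C@H]2CO[C@@H](CO)C2)c2nc(N)nc(O)c21` gives 83 uM, a number beyond the scatter below that of compound 2, so compound 3 needs less material for the same effect.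

Compound 4 `N#Cc1cccc(Cn2c(=O)n(C3OC(CO)[C@@H](O)[C@H]3O)c3nc(N)nc(O)c32)c1` has not yet been measured. Set against compound 2 the change is 3-cyanophenyl in place of carbamoyl on a saturated chain carbon bound to an aromatic nitrogen. A small group that can donate and accept a hydrogen bond is exchanged for a larger aromatic ring carrying a nitrile. Among the compounds with values here, no measured pair shows this kind of change, so the direction rests on weak ground; the two chains already seen on that nitrogen, in compound 1 and compound 2, give numbers within the scatter of each other.

The expected outcome for compound 4 is a modest move toward needing less material, estimated at 110 uM, with a range from 35 uM to 350 uM, which is an expected step of a 1.7-fold lower number from compound 2 to compound 4 (0.24 log units; within the scatter).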

Compound 4, concentration for half-maximal effect: 3 uM
Estimate against measurement, compound 4: 37-fold (1.56 log units) above; the whole stated range lies above it.
By their numbers in this assay, from the lowest: compound 4; then compounds 3, 1 and 2 (each within the scatter of the next, the first and the last beyond it).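

In this assay, within the data shown here, exchanging carbamoylmethyl for 3-cyanobenzyl gives a 63-fold lower number from compound 2 to compound 4 (1.80 log units; beyond the scatter), the first one-place comparison in this set, and it shows that the group on this nitrogen can change the number by a large margin. The change also bundles several differences together: the entering group has more heavy atoms, brings a six-membered aromatic ring and a nitrile, and has no hydrogen-bond donor, whereas the carbamoyl group it replaces has one, so this single step cannot show which of these differences matters. Nothing available here explains the size of the step.

A plain benzyl group, without the nitrile, would help separate the contribution of the ring from that of the nitrile, and a benzyl group carrying a methoxy group or a carboxylic acid in place of the nitrile would show how much depends on that particular substituent. As far as these compounds go, it also remains open whether 3-cyanobenzyl would produce a similar step on the core of compound 3, since this evidence comes from one pair on one core.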